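A Methoxy Group on Compound 3

The source may hold more compounds than are shown below. What is called first, only, known or untested is meant among the compounds shown, and "the series" means these compounds.

In a functional assay on PC-3 cells (Homo sapiens) for cytotoxicity, read by MTT assay, with a stated time of 72 h (on this read-out lower numbers stand for stronger inhibition and higher numbers for weaker inhibition), compound 3 `Cc1cc(/C=C/c2ccc(O)cc2)on1` gives 50200 nM, the higher of the two actual numbers in this small series. Compound 2 `Cc1cc(/C=C/c2ccc(O)c(O)c2)on1` gives 3300 nM. For compound 1 `COc1ccc(/C=C/c2cc(C)no2)cc1OC` the result is a limit of the assay, > 100000 nM.

Compound 4 `COc1cc(/C=C/c2cc(C)no2)ccc1O` has not yet been measured. It differs from compound 3 in one place: methoxy in place of hydrogen on an aromatic carbon, with methoxy in place of hydrogen on an aromatic carbon, ortho to a hydroxy group. Among the measured compounds shown here, one measured step bears on this carbon: a 15-fold higher number from compound 2 to compound 3 (1.18 log units; beyond the scatter), a large change beyond the scatter, with hydrogen in place of hydroxy. Compound 4 carries methoxy rather than hydroxy there, so that step is only a loose guide. Compound 1, which also carries methoxy, stands at the limit of > 100000 nM. A gain as large as the one shown by compound 2 is therefore not expected. The expected change is a moderate one towards a lower number, estimated as a 2.3-fold lower number from compound 3 to compound 4 (0.36 log units; beyond the scatter). For compound 4 the expected value is 22000 nM, with an estimated range of 6000 nM to 70000 nM.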

Compound 4, half-maximal inhibitory concentration: 20900 nM
Compound 4: the middle estimate sits 1.1-fold (0.02 log units) above what was measured; measured number inside the range.
By their numbers in this assay, from the lowest: compound 2; then compound 4; then compound 3. At a limit, above all of these: compound 1.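

Methoxy on this aromatic carbon, ortho to a hydroxy group, is not merely tolerated in this assay: it gives a 2.4-fold lower number from compound 3 to compound 4 (0.38 log units; beyond the scatter), so a lower number at this position does not depend on a hydroxy group alone. Hydroxy there still does better, with a 6.3-fold higher number from compound 2 to compound 4 (0.80 log units; beyond the scatter) on changing to methyl in place of hydrogen on that oxygen, which places methoxy between hydrogen and hydroxy in this series. Keeping a free hydroxy group in the series also matters, as hydrogen in place of methyl on an oxygen gives an at least 4.7-fold lower number from compound 1 to compound 4 (0.67 log units; beyond the scatter), a step that stands only as a bound since the value of compound 1 is a limit and not a number: the limit of > 100000 nM in this assay, at which 1 of the 4 values shown sits.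

The compounds shown carry only hydrogen, hydroxy or methoxy on this carbon. Going by these compounds, whether an amine or a longer chain such as ethoxy there would give a lower or a higher number remains open.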